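From 4-Methoxybenzyl to 4-Methylbenzyl

This account rests on a few compounds, and the source may have more. Where it says the series, first, only, none or still open, it means among the compounds named here.

In a functional assay, read by spectrophotometry, with a stated time of 30 min (on this read-out higher numbers stand for weaker inhibition and lower numbers for stronger inhibition), compound 1 `CC(C)(C)c1cc(CCC(=O)NCC2CCN(Cc3ccccc3)CC2)cc(C(C)(C)C)c1O` gives 63400 nM and compound 2 `COc1ccc(CN2CCC(CCNC(=O)/C=C/c3cc(C(C)(C)C)c(O)c(C(C)(C)C)c3)CC2)cc1` gives 61200 nM. Going by the values given here, these two values lie within the scatter of each other, so compound 2 stands level with the only other measured compound. The two structures differ in more than one place, so they offer no single-change step to reason from. Compound 3 `Cc1ccc(CN2CCC(CCNC(=O)/C=C/c3cc(C(C)(C)C)c(O)c(C(C)(C)C)c3)CC2)cc1` carries methyl in place of methoxy on an aromatic carbon, para to a large group (methyl in place of methoxy on an aromatic carbon). Starting from compound 2 at 61200 nM, and with no measured step of this kind to draw on, no change beyond the scatter is expected in this assay, in either direction. The expected size is a 1.0-fold lower number from compound 2 to compound 3 (0.01 log units; within the scatter). For compound 3 the estimate is 60000 nM, with an expected range of 25000 nM to 130000 nM.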

Compound 3, half-maximal inhibitory concentration: 60400 nM
Beside the measured number, compound 3's estimate is 1.0-fold (0.00 log units) below it; the range from low to high includes it.
By their numbers in this assay, from the lowest: compounds 3, 2 and 1 (each within the scatter of the next).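

In this assay, the result gives the only single-change comparison among these compounds: methyl in place of methoxy, on an aromatic carbon para to a large group, reads as a 1.0-fold lower number from compound 2 to compound 3 (0.01 log units; within the scatter). At this position, then, the methoxy oxygen and the hydrogen-bond acceptor counted with it can be exchanged for methyl without the read-out leaving the scatter, something the earlier pair, which differs in more than one place, could not show. Nothing available explains this outcome.

The compounds shown leave open whether any group at this carbon moves the number beyond the scatter, for example an amine, a carboxylic acid or a longer ethoxy chain. They also leave open whether a plain hydrogen there, on the same core, would read any differently.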